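The source may report more compounds than this note shows. Statements on the series, on what has been measured and on what is new or still open speak of the compounds shown alone.

Series notes, activation in an assay on mitochondria from L6 cells (Rattus norvegicus) for activation, with a stated time of 90 min; on this read-out lower numbers stand for an effect already at smaller amounts and higher numbers for an effect only at larger amounts of compound. Of the compounds shown here, two carry numbers so far. Compound 1, `Oc1nc2nonc2nc1Nc1ccc(OCC(F)(F)F)c(C(F)(F)F)c1`, gives 4000 nM in this assay. Compound 2, `Cc1ccc(CNc2nc3nonc3nc2O)cc1`, gives 53200 nM in this assay, the highest of the two numbers; compound 1 sits well under it, and that gap lies beyond the usual scatter. For the measured compounds named here, the two compounds differ in more than one place, so no single step can be drawn between them; their numbers show only that compound 1 is the lower of the pair.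

Compound 3, `Oc1nc2nonc2nc1NCc1ccc(OC(F)(F)F)cc1`, is not yet measured. It arises from compound 2 by one change: trifluoromethoxy in place of methyl on an aromatic carbon. The change sits on an aromatic carbon of a six-membered aromatic ring of carbon only. The only pointer at hand is compound 1, which carries fluorinated groups and gives the lower number, 4000 nM, but it also differs from compound 2 elsewhere, so it is a weak guide. The step from compound 2 to compound 3 is expected to be a 2.7-fold lower number from compound 2 to compound 3 (0.42 log units; beyond the scatter), downward, near the edge of the scatter. Compound 3 is estimated at 20000 nM, with a range from 6000 nM to 60000 nM.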

Compound 3, half-maximal effective concentration: 13400 nM
For compound 3 the middle estimate is 1.5-fold (0.17 log units) above the measured one; the measured number falls inside the stated range.
By their numbers in this assay, from the lowest: compound 1; then compound 3; then compound 2.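

In this assay, for the compounds shown here, this is the first step that can be read at a single place: a 4.0-fold lower number from compound 2 to compound 3 (0.60 log units; beyond the scatter), a modest change with trifluoromethoxy in place of methyl on an aromatic carbon, para to a large group. It shows that this position on the six-membered aromatic ring of carbon only accepts a group of more heavy atoms, including a hydrogen-bond acceptor, and that the number goes down rather than up with this exchange. No measurement at hand bears on why the number moves in this direction.

The step swaps carbon for oxygen, brings in fluorine and adds heavy atoms all at once, so it cannot say which of these goes with the lower number; methoxy or trifluoromethyl at the same place would separate them. Also open, from the compounds shown here alone, is how this position responds to groups of another kind, such as an amine or a carboxylic acid, and whether the exchange would give a similar step on another compound, since compound 1 differs from compound 3 in more than one place.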